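Shortening the Sulfanyl Chain: Cytotoxicity Outlook for Compound 4

The source may hold more compounds than are shown below. What is called first, only, known or untested is meant among the compounds shown, and "the series" means these compounds.

Compound 1 `CC(C)CSc1nc(N)nc2c1ncn2/C=C1/CC1(CO)CO` has no number in an ADME assay on MOLT-3 cells (Homo sapiens) for cytotoxicity, with a stated time of 7 days; on this read-out higher numbers stand for lower toxicity in this test and lower numbers for higher toxicity in this test; for compound 1 the entry reads "not determined" (no result reported). Its two measured companions give only limits. In this assay compound 2 `CCCCNc1nc(N)nc2c1ncn2/C=C1/CC1(CO)CO` stops at the limit of the test, > 20000 nM. Compound 3 `Nc1nc(OCC(F)(F)F)c2ncn(/C=C3/CC3(CO)CO)c2n1` in this assay likewise sits at a limit, > 20000 nM. The step that the two limits leave unreadable from compound 2 to compound 3 is therefore not readable, because both of its ends rest at the limit of > 20000 nM in this assay, at which 2 of the 3 values shown sit.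

Compound 4 `CSc1nc(N)nc2c1ncn2/C=C1/CC1(CO)CO` differs from compound 1 by hydrogen in place of isopropyl on a saturated chain carbon bound to a sulfur. Among the compounds with values here, no measured step covers this change, and compound 1 itself has no number to start from, so the step from compound 1 to compound 4 cannot be sized from the data. What the series does show is that every value obtained so far rests at the limit of > 20000 nM in this assay, at which 2 of the 3 values shown sit, whatever the group on the aromatic carbon, with compound 2 and compound 3 both behind that statement. On that basis compound 4 is expected to remain at the limit as well: the estimate for compound 4 is 20000 nM, within 10000 nM to 40000 nM, with a reported number rather than a limit considered unlikely.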

Compound 4, half-maximal cytotoxic concentration: > 20000 nM
Compound 4 gave a limit, no number (the forecaster's own chance of this, stated with the estimate: 85%); the middle value lies on the limit itself.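

Compound 4 gives a limit, not a number, so no new step can be read from compound 2 or compound 3 to compound 4: the limit of > 20000 nM in this assay, at which 3 of the 4 values shown sit.

The compounds shown leave open whether any group on the aromatic carbon gives a number rather than a limit in this assay.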